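A Bromo Group Tried at a Second Ring Position

A few compounds are considered here, and "the series" means these few. Any claim that something is new, unique, unknown or untested is made for them only; others in the source may bear on it.

Compound 1 `O=C(/C=C/c1ccccc1)c1ccc[nH]1` is the unsubstituted parent of this small set. In a functional assay on HL-60 cells (Homo sapiens) for inhibition, read by MTT assay, with a stated time of 48 h (on this read-out higher numbers stand for weaker inhibition and lower numbers for stronger inhibition), compound 1 gives only a limit of the assay, > 100000 nM. Its two measured relatives both carry substituents on the same ring: compound 2 `O=C(/C=C/c1ccccc1Br)c1ccc[nH]1` gives 42000 nM in this assay, and compound 3 `O=C(/C=C/c1cc([N+](=O)[O-])ccc1Cl)c1ccc[nH]1` gives 38000 nM. Going by the values given here, the only single-point step among the measured compounds, an at least 2.3-fold lower number from compound 1 to compound 2 (0.37 log units; beyond the scatter), counts as at least modest; it is read against the limit (the limit of > 100000 nM in this assay, at which 1 of the 3 values shown sits), so its full size stays open. Compound 4 `O=C(/C=C/c1ccc(Br)cc1)c1ccc[nH]1` has not yet been measured. It differs from compound 1 by bromo in place of hydrogen on an aromatic carbon. Because the step of an at least 2.3-fold lower number from compound 1 to compound 2 (0.37 log units; beyond the scatter) shows the same bromo group at another place on that ring lowering the number beyond the scatter, a drop of at least comparable size is expected for compound 4, with the caution that a new position need not repeat it. The expectation for compound 4 is therefore about 40000 nM in this assay, between 12000 nM and 100000 nM, an expected step of an at least 2.5-fold lower number from compound 1 to compound 4 (0.39 log units; beyond the scatter).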

Compound 4, half-maximal inhibitory concentration: 32000 nM
The estimate for compound 4 lay 1.3-fold (0.10 log units) above the measured number; low and high end bracket the measured number.
By their numbers in this assay, from the lowest: compounds 4, 3 and 2 (each within the scatter of the next). At a limit, above all of these: compound 1.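

In this assay, bromo in place of hydrogen on an aromatic carbon, here para to a group of 9 heavy atoms, gives an at least 3.1-fold lower number from compound 1 to compound 4 (0.49 log units; beyond the scatter). The lowering seen with compound 2 is therefore not confined to a single place on this ring: bromo at this second position also moves the number beyond the scatter. Compound 2 at 42000 nM and compound 4 at 32000 nM lie within the scatter of each other, so these values show no preference between the two positions.

Compound 1 gives only a limit of the assay, > 100000 nM, so the full size of the step stays open: the limit of > 100000 nM in this assay, at which 1 of the 4 values shown sits. The compounds shown also do not tell whether a methoxy group, an amine or a carboxylic acid at this position would lower the number as bromo does.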